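Lengthening an Alkoxy Chain in a Benzamide Acid Series

The compounds below may be only part of what the source reports. "The series", "measured", "known", "first", "only" and "open" are said of these compounds alone.

Three acids have been measured so far: compound 1 `O=C(O)c1cccc(OCc2ccc(Oc3ccccc3)cc2)c1`, compound 2 `COc1ccccc1C(=O)Nc1cccc(C(=O)O)c1` and compound 3 `COc1cccc(C(=O)Nc2cccc(C(=O)O)c2)c1`. In an assay on isolated protein for agonist activity at Bile acid receptor (Homo sapiens), read by TR-FRET, with a stated time of 3 h, in the absence of a further agent (on this read-out lower numbers stand for an effect already at smaller amounts and higher numbers for an effect only at larger amounts of compound), compound 1 gives > 10000 nM, which is a limit of the assay rather than a number. Compound 2 likewise stops at the limit, > 10000 nM. Among the measured compounds shown here, compound 3 gives 1040 nM, the only real number among the three, since the other two sit at the limit of > 10000 nM in this assay, at which 2 of the 3 values shown sit. Compound 4 `CCCCCOc1cccc(C(=O)Nc2cccc(C(=O)O)c2)c1` differs from compound 3 by butyl in place of hydrogen on a saturated chain carbon bound to an oxygen on an aromatic ring. For the measured compounds named here, no measured pair in this set shows a step of this kind, so the expectation rests on compound 3 alone. The expected step is a 3.5-fold lower number from compound 3 to compound 4 (0.54 log units; beyond the scatter), a modest gain beyond the scatter. Compound 4 is therefore estimated at 300 nM, within a range from 60 nM to 3000 nM.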

Compound 4, half-maximal effective concentration: 2540 nM
Beside the measured number, compound 4's estimate is 8.5-fold (0.93 log units) below it; the measured number falls inside the stated range.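

In this assay the change from methoxy to pentyloxy gives a 2.4-fold higher number from compound 3 to compound 4 (0.39 log units; beyond the scatter) and so moves the number the wrong way. Even so, compound 4 still gives a real number, 2540 nM, rather than a limit, so this position can carry a chain as long as pentyl without the effect disappearing. Nothing in the data shown explains this step.

From the compounds shown here alone, whether ethoxy or propoxy chains would fall between these two values remains open, as does the outcome with a longer chain such as octyloxy. The effect of an amine at the end of the chain is also unknown.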